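Thiosemicarbazone series: aryl changes and growth inhibition

The compounds below may be only part of what the source reports. "The series", "measured", "known", "first", "only" and "open" are said of these compounds alone.

Measured so far: compound 1 `COc1ccc(/C=N\NC(=S)NC(C)(C)CCC[C@](C)(O)[C@@H]2CC=C(C)CC2)cc1` gives 6730 nM; compound 2 `CC1=CC[C@@H]([C@@](C)(O)CCCC(C)(C)NC(=S)N/N=C\c2cccc([N+](=O)[O-])c2)CC1` gives 6720 nM; compound 3 `CC1=CC[C@@H]([C@@](C)(O)CCCC(C)(C)NC(=S)N/N=C\c2ccc([N+](=O)[O-])cc2)CC1` gives 12800 nM.

In a functional assay on NCI/ADR cells (Homo sapiens) for cytotoxicity, read by sulforhodamine B assay (a lower number here means a stronger inhibitor of growth, a higher number a weaker inhibitor of growth), compound 1 stands second highest of the three numbers, with compound 2 nearest and compound 3 furthest: a 1.0-fold lower number from compound 1 to compound 2 (0.00 log units; within the scatter) and a 1.9-fold higher number from compound 1 to compound 3 (0.28 log units; within the scatter). Compound 4 `CC1=CC[C@@H]([C@@](C)(O)CCCC(C)(C)NC(=S)N/N=C(/C)c2ccccc2)CC1` differs from compound 1 by a group of 9 heavy atoms (8 carbon, 1 nitrogen; one six-membered aromatic ring of carbon only) in place of a group of 10 heavy atoms (8 carbon, 1 nitrogen, 1 oxygen; one six-membered aromatic ring of carbon only), on an amide-type nitrogen. Among the compounds with values here, none of the measured steps touches the carbon with the double bond to nitrogen; the steps that bear on the aryl part, a 1.0-fold lower number from compound 1 to compound 2 (0.00 log units; within the scatter) and a 1.9-fold higher number from compound 2 to compound 3 (0.28 log units; within the scatter), both stayed within the scatter. No step beyond the scatter is therefore expected in this assay, in either direction. Compound 4 is estimated at 7000 nM, range 3000 nM to 16000 nM. The expected step is a 1.0-fold higher number from compound 1 to compound 4 (0.02 log units; within the scatter).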

Compound 4, concentration for 50% growth inhibition: 750 nM
The estimate for compound 4 lay 9.3-fold (0.97 log units) above the measured number, and the stated range ends above it.
By their numbers in this assay, from the lowest: compound 4; then compounds 2, 1 and 3 (each within the scatter of the next).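

In this assay, within the data shown here, the group on the amide-type nitrogen gives a 9.0-fold lower number from compound 1 to compound 4 (0.95 log units; beyond the scatter) as the only step so far beyond the scatter, so this position can shift growth inhibition, which the aryl changes among compound 1, compound 2 and compound 3 did not show. The exchange removes the methoxy and brings in a methyl in a single step, and the two cannot be separated here. No evidence on the cause of this step is available.

From the compounds shown here alone, whether the methyl alone carries the step remains open. Also open, going by these compounds, is what an ethyl in its place, or a methoxy on the phenyl ring of compound 4, would give.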